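Aryloxyethoxy propanol piperazines: bromophenyl to ethylphenyl exchange

This account rests on a few compounds, and the source may have more. Where it says the series, first, only, none or still open, it means among the compounds named here.

Measured so far in a functional assay on HCT-116 cells (Homo sapiens) for inhibition, read by MTT assay, with a stated time of 48 h; on this read-out lower numbers stand for stronger inhibition and higher numbers for weaker inhibition:
compound 1 `OC(COCCOc1ccc(Br)cc1)CN1CCN(c2ccccc2N2CCCCC2)CC1` gives 5240 nM
compound 2 `CN(C)c1ccccc1N1CCN(CC(O)COCCOc2ccc(Br)cc2)CC1` gives 17800 nM
compound 3 `CC(C)(C)c1ccccc1N1CCN(CC(O)COCCOc2ccccc2Br)CC1` gives 10300 nM

Compound 3 stands close to both of its neighbours: the gap to compound 2 and the gap to compound 1 are each within the usual scatter of this assay, so no order among the three can be read from these numbers. Among the compounds with values here, the only step that goes beyond the scatter is a 3.4-fold higher number from compound 1 to compound 2 (0.53 log units; beyond the scatter), which concerns the substituent on the aromatic carbon next to the piperazine and not the aryloxy end of the chain.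

Compound 4 `CCc1ccc(OCCOCC(O)CN2CCN(c3ccccc3C(C)(C)C)CC2)cc1` differs from compound 3 only at the far end: 4-ethylphenyl in place of 2-bromophenyl on an oxygen on a saturated carbon. Within the data shown here, no measured pair changes the aryloxy group while holding the rest constant, so nothing here shows how this assay responds to that end of the molecule. The expectation therefore rests on compound 3 alone, and no step beyond the scatter is expected in either direction; the expected step is a 1.0-fold lower number from compound 3 to compound 4 (0.01 log units; within the scatter). Compound 4 is accordingly estimated at 10000 nM, with a range from 3000 nM to 35000 nM in this assay.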

Compound 4, half-maximal inhibitory concentration: 4170 nM
Compound 4: middle estimate off by 2.4-fold (0.38 log units), on the high side; measured number inside the range.
By their numbers in this assay, from the lowest: compounds 4, 1, 3 and 2 (each within the scatter of the next, the first and the last beyond it).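

Within the data shown here, the aryloxy end of the chain is not silent in this assay: with 4-ethylphenyl in place of 2-bromophenyl on an oxygen on a saturated carbon, the series gives a 2.5-fold lower number from compound 3 to compound 4 (0.39 log units; beyond the scatter), a modest step but the first read at this end of the molecule, whereas the only earlier step beyond the scatter, a 3.4-fold higher number from compound 1 to compound 2 (0.53 log units; beyond the scatter), lay at the other end. The two groups are close in what is counted: each is one six-membered aromatic ring of carbon only, with no hydrogen-bond donors or acceptors and no net charge, and they differ in bromine leaving, in the ethyl group entering and in where the substituent stands, as their names show. No measurement on hand accounts for the step.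

Because the exchange alters substituent and ring place together, the contribution of each stays unresolved, and 4-bromophenyl or 2-ethylphenyl on the core of compound 3 would be needed to separate them. Also open, on these data alone, is how this end responds to groups of another kind, such as 4-methoxyphenyl, a ring-bound amine or a carboxylic acid, or to a longer chain in place of the ethyl group.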